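The source may report more compounds than this note shows. Statements on the series, on what has been measured and on what is new or still open speak of the compounds shown alone.

Measured so far in a functional assay on NCI-H1299 cells (Homo sapiens) for antiproliferative activity, read by CCK-8 assay, with a stated time of 72 h; on this read-out higher numbers stand for weaker inhibition and lower numbers for stronger inhibition:
- compound 1 `CCOc1cc(C(C)(C)C)ccc1C1=NC(c2ccc(Cl)cc2)C(c2ccc(Cl)cc2)N1C(=O)NCCCCCCCC(=O)NO`: 9060 nM
- compound 2 `CCOc1cc(C(C)(C)C)ccc1C1=NC(c2ccc(Cl)cc2)C(c2ccc(Cl)cc2)N1C(=O)N1CCN(Cc2ccc(C(=O)NO)cc2)CC1`: 3000 nM

Compound 2 holds the lower of the two numbers at 3000 nM, and its gap to compound 1 lies beyond the scatter. Among the compounds with values here, these two compounds differ in more than one place, so the series offers no measured single-place step as a guide.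

Next comes compound 3 `CCOc1cc(C(C)(C)C)ccc1C1=NC(c2ccc(Cl)cc2)C(c2ccc(Cl)cc2)N1C(=O)N1CCN(c2ncc(C(=O)NO)cn2)CC1`, with the change (5-(hydroxycarbamoyl)pyrimidin-2-yl in place of 4-(hydroxycarbamoyl)benzyl on an amine nitrogen in a ring). It carries 5-(hydroxycarbamoyl)pyrimidin-2-yl in place of 4-(hydroxycarbamoyl)benzyl on an amine nitrogen in a ring.

Within the data shown here, with no measured step to draw on, no step beyond the scatter is expected in this assay, in either direction. The estimated change is small, a 1.2-fold lower number from compound 2 to compound 3 (0.08 log units; within the scatter), and the reference is compound 2 at 3000 nM.

For compound 3 the expected value is 2500 nM, with an estimated range of 900 nM to 7000 nM.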

Compound 3, half-maximal inhibitory concentration: 5450 nM
Compound 3: the middle estimate sits 2.2-fold (0.34 log units) below what was measured; the measured number falls inside the stated range.
By their numbers in this assay, from the lowest: compounds 2, 3 and 1 (each within the scatter of the next, the first and the last beyond it).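

At the amine nitrogen in the six-membered non-aromatic ring with 2 nitrogen, placing 5-(hydroxycarbamoyl)pyrimidin-2-yl in place of 4-(hydroxycarbamoyl)benzyl gives a 1.8-fold higher number from compound 2 to compound 3 (0.26 log units; within the scatter) in this assay, the first single-place step available in the series. This position therefore accepts an exchange of the carbon-only aromatic ring for one with 2 hetero atoms, along with a rise from 2 to 4 hydrogen-bond acceptors, without a shift beyond the usual scatter. No evidence is available that bears on this result.

As far as these compounds go, whether a pyridine ring, or a carboxylic acid in place of the hydroxycarbamoyl group, would hold the number at this position remains open. Compound 1 differs from compound 2 and compound 3 in more than one place, so the contribution of its chain cannot be separated out.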